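Carbamate chain extension on the shared core

The source may report more compounds than this note shows. Statements on the series, on what has been measured and on what is new or still open speak of the compounds shown alone.

Compound 1 `CCCOC(=O)Nc1ccc([Se]C#N)cc1` stands at the high end of the two numbers recorded in a functional assay on PC-3 cells (Homo sapiens) for cytotoxicity, read by MTT assay, with a stated time of 72 h; on this read-out lower numbers stand for stronger inhibition of growth and higher numbers for weaker inhibition of growth: compound 1 gives 21100 nM. Among the compounds with values here, compound 2 `O=C(Nc1ccc([Se][Se]c2ccc(NC(=O)OCc3ccccc3)cc2)cc1)OCc1ccccc1`, built on a different core, gives 100 nM in this assay, and the gap between the two values lies well beyond the scatter; since the two compounds differ in more than one place, no single step between them is computed, and only the two values themselves can be compared. Compound 3 `CCCCCCOC(=O)Nc1ccc([Se]C#N)cc1` keeps the core of compound 1 and differs from it by one change, (propyl in place of hydrogen on a saturated chain carbon, three bonds along the chain from an oxygen next to a carbonyl group). Within the data shown here, no measured pair shows this change, so its effect cannot be read from the data in hand. A modest step toward a lower number is expected, with a fair chance that it remains within the scatter. The expected step is a 1.8-fold lower number from compound 1 to compound 3 (0.25 log units; within the scatter). Compound 3 is estimated at 12000 nM, with a range from 3000 nM to 40000 nM.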

Compound 3, concentration for 50% growth inhibition: 17300 nM
Compound 3: middle estimate off by 1.4-fold (0.16 log units), on the low side; low and high end bracket the measured number.
By their numbers in this assay, from the lowest: compound 2; then compounds 3 and 1 (each within the scatter of the next).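

Within the data shown here, the first measured step at this position, in this assay, reads a 1.2-fold lower number from compound 1 to compound 3 (0.09 log units; within the scatter) and rests on propyl in place of hydrogen on a saturated chain carbon, three bonds along the chain from an oxygen next to a carbonyl group. Within this pair, the read-out does not separate the propyl and hexyl chains, so this extension gives no measurable step on the core of compound 1. No measurement in hand bears on the reason for this result.

A single step cannot show whether a longer chain such as octyl would separate from compound 1. Also open, on these data alone, is whether a chain ending in an amine or a carboxylic acid, or a phenyl ring at the chain end, would give a step beyond the scatter.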